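Adding bromo to the phenyl ring of compound 3

This account rests on a few compounds, and the source may have more. Where it says the series, first, only, none or still open, it means among the compounds named here.

- compound 1 `CC1(C)[C@H]2CC[C@]1(C)N(Cc1cn(-c3ccc(C#N)cc3)nn1)C(=O)C2` gives 500 nM
- compound 2 `CC1(C)[C@H]2CC[C@]1(C)N(Cc1cn(-c3ccccc3F)nn1)C(=O)C2` gives 300 nM
- compound 3 `CC1(C)[C@H]2CC[C@]1(C)N(Cc1cn(-c3ccccc3)nn1)C(=O)C2` gives 240 nM

In a functional assay on SGC-7901 cells (Homo sapiens) for inhibition, read by MTT assay, with a stated time of 24 h (a lower number here means a stronger inhibitor, a higher number a weaker inhibitor), compound 3 gives 240 nM. The data show a 1.3-fold lower number from compound 2 to compound 3 (0.10 log units; within the scatter), so these two cannot be told apart. They also show a 2.1-fold lower number from compound 1 to compound 3 (0.32 log units; beyond the scatter), a modest but real gap.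

Compound 4 `CC1(C)[C@H]2CC[C@]1(C)N(Cc1cn(-c3ccc(Br)cc3)nn1)C(=O)C2` has not yet been measured. It replaces phenyl with 4-bromophenyl, with bromo in place of hydrogen on an aromatic carbon, para to a large group (bromo in place of hydrogen on an aromatic carbon).

Going by the values given here, no bromo compound has been measured, so the guidance is indirect. The closest case is compound 1, a 4-cyanophenyl, whose value of 500 nM suggests that a group at this spot may raise the number a little. Compound 2, a 2-fluorophenyl, carries its group elsewhere on the ring and offers less guidance.

The expected change in this assay is a 1.4-fold higher number from compound 3 to compound 4 (0.15 log units; within the scatter), a small rise that may not clear the scatter. For compound 4 the estimate is 340 nM, with an expected range from 150 nM to 750 nM.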

Compound 4, half-maximal inhibitory concentration: 450 nM
The estimate for compound 4 lay 1.3-fold (0.12 log units) below the measured number, and the stated range covers the measured number.
By their numbers in this assay, from the lowest: compounds 3, 2, 4 and 1 (each within the scatter of the next, the first and the last beyond it).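

In this assay bromo in place of hydrogen on the phenyl ring gives a 1.9-fold higher number from compound 3 to compound 4 (0.27 log units; within the scatter) so this carbon, para to a large group, carries a bromine atom with no change that can be told from scatter. Bromo in place of cyano gives a 1.1-fold lower number from compound 1 to compound 4 (0.05 log units; within the scatter) and 4-bromophenyl in place of 2-fluorophenyl gives a 1.5-fold higher number from compound 2 to compound 4 (0.18 log units; within the scatter) so compound 4 cannot be told apart from either, and it sits within the scatter of compound 3 and compound 1 even though those two lie beyond it from each other. Nothing measured here explains these numbers.

As far as these compounds go, whether an amine or a carboxylic acid on this carbon would move the number beyond the scatter from compound 3 stays open. So does the outcome for chloro or a longer chain at the same spot.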